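Benzamide para-methylsulfonyl step on the shared core

The source may hold more compounds than are shown below. What is called first, only, known or untested is meant among the compounds shown, and "the series" means these compounds.

The series shares one core and varies only the amide-bearing ring. Compound 1 `O=C(Nc1ccc(Cl)c(-c2nnc3c(Cl)cccn23)c1)c1ccccc1` gives 58200 nM in a functional assay on MDA-MB-231 cells (Homo sapiens) for antiproliferative activity, read by MTT assay, with stated times of 72 h and 4 h (a higher number here means a weaker inhibitor, a lower number a stronger inhibitor), the lowest number among the three measured compounds, though none of the others differs from it beyond the scatter. Compound 2 `O=C(Nc1ccc(Cl)c(-c2nnc3c(Cl)cccn23)c1)c1ccccc1Cl` gives 59900 nM in this assay; the step of a 1.0-fold higher number from compound 1 to compound 2 (0.01 log units; within the scatter) is within the scatter. Compound 3 `O=C(Nc1ccc(Cl)c(-c2nnc3c(Cl)cccn23)c1)c1ccccn1` gives 92000 nM in this assay; the step of a 1.6-fold higher number from compound 1 to compound 3 (0.20 log units; within the scatter) and the step of a 1.5-fold higher number from compound 2 to compound 3 (0.19 log units; within the scatter) are likewise within the scatter. Compound 4 `CS(=O)(=O)c1ccc(C(=O)Nc2ccc(Cl)c(-c3nnc4c(Cl)cccn34)c2)cc1` has not been measured. It differs from compound 1 by methylsulfonyl in place of hydrogen on an aromatic carbon. Going by the values given here, no measured step places a group on that ring position, so the two steps that bear on it are only indirect: both changes to the amide-bearing ring in this set, from compound 1 to compound 2 and from compound 1 to compound 3, stayed within the scatter. On that basis no step beyond the scatter is expected for compound 4 in this assay; the estimated step is a 1.0-fold higher number from compound 1 to compound 4 (0.01 log units; within the scatter). Compound 4 is therefore expected to give about 60000 nM in this assay, with a range from 25000 nM to 150000 nM.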

Compound 4, half-maximal inhibitory concentration: > 100000 nM
Compound 4 gave a limit, no number; the forecaster's own chance of this, stated with the estimate: 15%; middle value at least 1.6-fold (0.22 log units) away from the limit.
By their numbers in this assay, from the lowest: compounds 1, 2 and 3 (each within the scatter of the next). At a limit, above all of these: compound 4.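

In this assay compound 4 gives a limit and not a number, the only one in this set: the limit of > 100000 nM in this assay, at which 1 of the 4 values shown sits. The steps to it are floors: an at least 1.7-fold higher number from compound 1 to compound 4 (0.23 log units; that floor lies within the scatter), an at least 1.6-fold higher number from compound 2 to compound 4 (0.22 log units; that floor lies within the scatter) and an at least 1.0-fold higher number from compound 3 to compound 4 (0.03 log units; that floor lies within the scatter), so their true sizes cannot be read, and none is shown to exceed the scatter. Going by these compounds alone, still, this is the first look at a group on the ring carbon para to a large group, and methylsulfonyl in place of hydrogen there gives no sign of a stronger inhibitor than compound 1, which the earlier changes to the amide-bearing ring could not show for this position.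

The compounds shown leave open whether methylsulfonyl truly weakens the series in this assay or merely leaves it near the values of compounds 1, 2 and 3, since a limit cannot separate the two readings. They also leave open whether a different group on the same aromatic carbon, such as an amine, a carboxylic acid or a methoxy group, would return a number that could be compared with compound 1.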